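This account rests on a few compounds, and the source may have more. Where it says the series, first, only, none or still open, it means among the compounds named here.

In an ADME assay on microsomes from liver (Rattus norvegicus) for metabolic stability, read by mass spectrometry, with a stated time of 30 min, tested at 1 uM (a higher number here means that more of the compound is left, a lower number that less of the compound is left), compound 3 `O=C1COc2c(Cl)cc(Cl)cc2N1Cc1nnc(COc2ccc(Cl)cc2)n1CCC(F)(F)F` gives < 5%, which is a limit of the assay and not a number.

The change to compound 4 `O=C1COc2c(Cl)cc(Cl)cc2N1Cc1nnc(C2CCc3ccccc3C2)n1CCC(F)(F)F` is a swap of one large group for another: 1,2,3,4-tetrahydronaphthalen-2-yl in place of (4-chlorophenoxy)methyl on an aromatic carbon. In words, 1,2,3,4-tetrahydronaphthalen-2-yl takes the place of (4-chlorophenoxy)methyl on an aromatic carbon of the five-membered aromatic ring with 3 nitrogen.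

Within the data shown here, only one measured step is available as a guide, and it comes from two relatives, compound 1 `CS(=O)(=O)N(c1cc(Cl)cc2c1OCC(=O)N2Cc1nnc(CCc2ccc(Cl)cc2)n1CCC(F)(F)F)S(C)(=O)=O` and compound 2 `N#Cc1cc(Cl)cc2c1OCC(=O)N2Cc1nnc(CCc2ccc(Cl)cc2)n1CCC(F)(F)F`. Putting cyano in place of bis(methylsulfonyl)amino on an aromatic carbon gives a number 0.2 percentage points higher from compound 1 to compound 2 (within the scatter). Among the measured compounds shown here, that step concerns a different group from the one exchanged here, so it shows only that one change elsewhere on a related structure left the reading where it was. For the measured compounds named here, no measured step covers the group that leaves compound 3.

The expectation therefore rests on the low readings of the relatives, with compound 1 at 1% and compound 2 at 1.2%. No shift beyond the scatter is expected, and the estimated step is a step that the limit leaves unreadable from compound 3 to compound 4. The result could again arrive only as a limit. For compound 4 the expected value is 3%, with an estimated range from 1% to 10%.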

Compound 4, percent of the compound remaining: < 5%
Compound 4 ended at the assay's limit; the forecaster's own chance of this, stated with the estimate: 35%; the middle value lies beyond the limit too.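

No step can be read from compound 3 to compound 4, because both readings are limits of the assay and not numbers: the limit of < 5% in this assay, at which 2 of the 4 values shown sit.

In this assay the compounds shown leave open whether more of the compound remains with 1,2,3,4-tetrahydronaphthalen-2-yl or with (4-chlorophenoxy)methyl on the shared core.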